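Swapping a Fluorophenyl Tail for Cyclohexyl on an Amide

The compounds below may be only part of what the source reports. "The series", "measured", "known", "first", "only" and "open" are said of these compounds alone.

Compound 1 `O=C(CCc1ccc(-c2ccc(F)cc2)cc1)N1CCCC1`: 3400 nM
Compound 2 `COc1ccc(CCCCCCC(=O)N2CCCC2)cc1`: 35400 nM
Compound 3 `CCCc1cccc(CCCCCCC(=O)N2CCCC2)c1`: given only as a limit of the assay, > 100000 nM

These values come from an assay on HEK293 cells for inhibition of N-acylethanolamine-hydrolyzing acid amidase (Rattus norvegicus), read by LC-MS, with a stated time of 30 min; on this read-out higher numbers stand for weaker inhibition and lower numbers for stronger inhibition. Of the two plain numbers, compound 1 has the lowest; compound 2 sits at a higher number, and that gap lies beyond the usual scatter. Compound 3 reaches only a limit, not a number. Compound 4 `O=C(CCc1ccc(C2CCCCC2)cc1)N1CCCC1` has not yet been measured. It differs from compound 1 by cyclohexyl in place of 4-fluorophenyl on an aromatic carbon. Within the data shown here, no measured pair shows such a step, so the expectation rests on compound 1 alone. The step of a 1.4-fold lower number from compound 1 to compound 4 (0.13 log units; within the scatter) is expected to stay within the scatter, in no clear direction. The estimate for compound 4 is 2500 nM, within 600 nM to 10000 nM.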

Compound 4, half-maximal inhibitory concentration: 500 nM
The estimate for compound 4 lay 5.0-fold (0.70 log units) above the measured number, outside the stated range (below it).
By their numbers in this assay, from the lowest: compound 4; then compound 1; then compound 2. At a limit, above all of these: compound 3.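

In this assay, the change at this position, on an aromatic carbon, gives a 6.8-fold lower number from compound 1 to compound 4 (0.83 log units; beyond the scatter), beyond the usual scatter. An aromatic ring at this spot is therefore not needed for inhibition in this pair, and a non-aromatic cyclohexyl ring does better than 4-fluorophenyl. Nothing measured here gives a reason for this step. Still open, going by these compounds, is whether a smaller ring such as cyclopentyl, an open hexyl chain, or a cyclohexyl ring carrying an amine or a carboxylic acid would keep this gain.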